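Methoxycarbonyl in Place of Chloro on the Aryl Ring

A few compounds are considered here, and "the series" means these few. Any claim that something is new, unique, unknown or untested is made for them only; others in the source may bear on it.

Three compounds share a common core and differ only in the group that sits on a six-membered aromatic ring of carbon only. Compound 1 `Cc1ccc(-c2cc(N3CCC(CNS(N)(=O)=O)CC3)ncn2)cc1` carries methyl and in a functional assay on MCF7 cells (Homo sapiens) for antiproliferative activity, read by sulforhodamine B assay, with a stated time of 48 h (on this read-out higher numbers stand for weaker inhibition of growth and lower numbers for stronger inhibition of growth), compound 1 gives 30600 nM. Compound 2 `COc1ccc(-c2cc(N3CCC(CNS(N)(=O)=O)CC3)ncn2)cc1` carries methoxy and in this assay compound 2 gives 35300 nM. Compound 3 `NS(=O)(=O)NCC1CCN(c2cc(-c3ccc(Cl)cc3)ncn2)CC1` carries chloro and in this assay compound 3 gives 25500 nM. Compound 3 has the lowest of the three numbers, yet the steps of a 1.2-fold lower number from compound 1 to compound 3 (0.08 log units; within the scatter) and a 1.4-fold lower number from compound 2 to compound 3 (0.14 log units; within the scatter) are within the scatter, as is a 1.2-fold higher number from compound 1 to compound 2 (0.06 log units; within the scatter), so the three compounds cannot be told apart on these data.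

Compound 4 `COC(=O)c1ccc(-c2cc(N3CCC(CNS(N)(=O)=O)CC3)ncn2)cc1` brings a new change: methoxycarbonyl in place of chloro on an aromatic carbon. The three measured steps bear on it only loosely, since each swapped one small substituent for another at this same position and none moved the number beyond the scatter. Nothing measured here covers a methoxycarbonyl group. The step of a 1.2-fold higher number from compound 3 to compound 4 (0.07 log units; within the scatter) is therefore expected to be small, with no shift beyond the scatter in this assay. Compound 4 is expected to give 30000 nM, in a range from 12000 nM to 75000 nM.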

Compound 4, concentration for 50% growth inhibition: 17700 nM
Beside the measured number, compound 4's estimate is 1.7-fold (0.23 log units) above it; the measured number falls inside the stated range.
By their numbers in this assay, from the lowest: compounds 4, 3, 1 and 2 (each within the scatter of the next).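

Even the methoxycarbonyl group, larger than chloro and the only group here with a double bond outside aromatic rings, leaves the number at this position, para to a large group, within the scatter in this assay (a 1.4-fold lower number from compound 3 to compound 4 (0.16 log units; within the scatter)). The same holds against the two other groups (a 2.0-fold lower number from compound 2 to compound 4 (0.30 log units; within the scatter); a 1.7-fold lower number from compound 1 to compound 4 (0.24 log units; within the scatter)), so all four compounds remain within the scatter of one another and this change gives no clear separation. No measurement shown here offers an explanation for these small steps.

Going by these compounds, it remains open whether an amine, a carboxylic acid or a longer chain at this position would move the number beyond the scatter in this assay. On these data alone, it also remains open whether the free carboxylic acid would behave like its methoxycarbonyl counterpart in compound 4.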